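The compounds below may be only part of what the source reports. "The series", "measured", "known", "first", "only" and "open" are said of these compounds alone.

Measured so far in a functional assay on HL-60 cells (Homo sapiens) for inhibition, read by CCK-8 assay, with a stated time of 48 h; on this read-out lower numbers stand for stronger inhibition and higher numbers for weaker inhibition:

compound 1, `O=C(Nc1cccc([N+](=O)[O-])c1)N1CCN(S(=O)(=O)c2sccc2-c2ccccc2Oc2ccc(O)c(O)c2)CC1`, gives 4500 nM
compound 2, `COc1ccc(Oc2ccccc2-c2ccsc2S(=O)(=O)N2CCN(C(=O)Nc3cccc([N+](=O)[O-])c3)CC2)cc1OC`, gives only a limit of the assay, > 50000 nM
compound 3, `COc1ccc(Oc2ccc(C(C)C)cc2-c2ccsc2S(=O)(=O)NCCNC(=S)Nc2cc(C(F)(F)F)cc(C(F)(F)F)c2)cc1OC`, gives 6900 nM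

Compound 3 stands highest of the two numbers, with compound 1 nearest to it; the gap between them is within the scatter, so no order is read from it. Compounds 1 and 2 differ in one place: 3,4-dihydroxyphenyl in place of 3,4-dimethoxyphenyl on an oxygen on an aromatic ring. This change gives an at least 11-fold lower number from compound 2 to compound 1 (1.04 log units; beyond the scatter). The size of that step is bounded only on one side because compound 2 sits at the limit of > 50000 nM in this assay, at which 1 of the 3 values shown sits.

Compound 4, `CC(C)c1ccc(Oc2ccc(O)c(O)c2)c(-c2ccsc2S(=O)(=O)NCCNC(=S)Nc2cc(C(F)(F)F)cc(C(F)(F)F)c2)c1`, is not yet measured in this assay. It differs from compound 3 in one place: 3,4-dihydroxyphenyl in place of 3,4-dimethoxyphenyl on an oxygen on an aromatic ring. The place is the same, word for word, as in the pair of compound 2 and compound 1, so this is the same change made on a different core. How the core of compound 3 differs from the core of compound 2 is not broken down here.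

On the one earlier occurrence, the change lowered the number by a large step; as compound 3 starts from a measured number rather than a limit, a lowering of similar direction but smaller certain size is expected, a 5.8-fold lower number from compound 3 to compound 4 (0.76 log units; beyond the scatter), beside the earlier at least 11-fold lower number from compound 2 to compound 1 (1.04 log units; beyond the scatter). Compound 4 is therefore estimated at 1200 nM in this assay, with the expected range from 400 nM to 4000 nM.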

Compound 4, half-maximal inhibitory concentration: 8200 nM
Compound 4: middle estimate off by 6.8-fold (0.83 log units), on the low side, outside the stated range (above it).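

In this assay, among the compounds shown here, the change from 3,4-dimethoxyphenyl to 3,4-dihydroxyphenyl on the second core gives a 1.2-fold higher number from compound 3 to compound 4 (0.07 log units; within the scatter) and so yields no order within that pair, in contrast to the large lowering seen on the first core. Set side by side, the two occurrences of the same change do not agree: the same change on two cores in this assay, an at least 11-fold lower number (1.04 log units; beyond the scatter) from compound 2 to compound 1 and a 1.2-fold higher number (0.07 log units; within the scatter) from compound 3 to compound 4, at least 13-fold (1.12 log units) apart, beyond the scatter of two such steps. The lowering seen on the core of compound 1 therefore cannot be assumed to travel with the change to another core, but two pairs do not show how general either outcome is, what sets them apart, or the full size of the earlier step, which is open on one side as compound 2 gives only a limit of the assay: the limit of > 50000 nM in this assay, at which 1 of the 4 values shown sits.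

The cores of compound 1 and compound 3 differ in more than one place, and the compounds shown leave open which of those differences decides whether the change lowers the number. They also leave open how a single hydroxy group, an amine or a carboxylic acid on that same aromatic ring would read on each of the two cores.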